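Ester tail changes and rat microsomal half-life

The compounds below may be only part of what the source reports. "The series", "measured", "known", "first", "only" and "open" are said of these compounds alone.

Measured so far:
compound 1 `CCOc1cc(NC(=O)C2(NC(=O)c3ccc4c(C5CCCC5)c(-c5ncc(Cl)cn5)n(C)c4c3)CCC2)ccc1/C=C/C(=O)OCOP(=O)(O)O` — 0.15 h
compound 2 `CCOc1cc(NC(=O)C2(NC(=O)c3ccc4c(C5CCCC5)c(-c5ncc(Cl)cn5)n(C)c4c3)CCC2)ccc1/C=C/C(=O)OCC(C)C` — 1.42 h

Among the measured compounds shown here, in an ADME assay (liver) for pharmacokinetics, with Liver microsome (Rattus norvegicus) as the target, using microsomes (a lower number here means that the compound disappears faster, a higher number that the compound lasts longer), compound 2 gives 1.42 h, the higher of the two numbers; the only measured step, a 9.5-fold higher number from compound 1 to compound 2 (0.98 log units; beyond the scatter), is a modest one. Compound 3 `CCOc1cc(NC(=O)C2(NC(=O)c3ccc4c(C5CCCC5)c(-c5ncc(Cl)cn5)n(C)c4c3)CCC2)ccc1/C=C/C(=O)OCC(=O)N1CCCC1` differs from compound 2 by (pyrrolidin-1-yl)carbonyl in place of isopropyl on a saturated chain carbon bound to an oxygen next to a carbonyl group. For the measured compounds named here, the step from compound 1 to compound 2 concerns a different exchange at that place, so it bears on compound 3 only loosely, and no closer analogue exists. A change in the same direction as a 9.5-fold higher number from compound 1 to compound 2 (0.98 log units; beyond the scatter) is not expected. The step expected here is a 2.0-fold lower number from compound 2 to compound 3 (0.31 log units; beyond the scatter), which lies near the scatter. Compound 3 is therefore estimated at 0.7 h, range 0.25 h to 2 h.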

Compound 3, half-life: 1.47 h
Beside the measured number, compound 3's estimate is 2.1-fold (0.32 log units) below it; low and high end bracket the measured number.
By their numbers in this assay, from the lowest: compound 1; then compounds 2 and 3 (each within the scatter of the next).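

In this assay, the larger (pyrrolidin-1-yl)carbonyl, with its ring and hydrogen-bond acceptor, reads the same as isopropyl on this saturated chain carbon (a 1.0-fold higher number from compound 2 to compound 3 (0.02 log units; within the scatter)). Against the phosphorus-bearing group of compound 1, it gives a step (a 9.8-fold higher number from compound 1 to compound 3 (0.99 log units; beyond the scatter)) of the same order as the one seen with isopropyl (a 9.5-fold higher number from compound 1 to compound 2 (0.98 log units; beyond the scatter)). No measurement at hand accounts for this match between two such different groups. Still open, on these data alone, is how an amine, a carboxylic acid or a longer chain on this carbon would read in this assay.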